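This account rests on a few compounds, and the source may have more. Where it says the series, first, only, none or still open, it means among the compounds named here.

- Compound 1 `COC(=O)CC1CNC(=O)c2cc(Br)c(Br)n21`: 79000 nM
- Compound 2 `COC(=O)CC1CNC(=O)c2cccn21`: > 200000 nM

Both compounds were tested in a functional assay on PC-3 cells (Homo sapiens) for cytotoxicity, read by CCK-8 assay, with a stated time of 72 h; on this read-out lower numbers stand for stronger inhibition and higher numbers for weaker inhibition. Compound 2 stands at a limit of this assay and has no exact number: > 200000 nM. Compound 3 `COC(=O)CC1CNC(=O)c2ccc(Br)n21` differs from compound 2 in one place: bromo in place of hydrogen on an aromatic carbon. In this assay, a modest move towards stronger inhibition is expected because compound 1, which also bears bromo, gives 79000 nM. The expected size is an at least 1.5-fold lower number from compound 2 to compound 3 (0.18 log units; that floor lies within the scatter), which may not clear the usual scatter. Compound 3 is estimated at 130000 nM, with an expected range of 65000 nM to 260000 nM.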

Compound 3, half-maximal inhibitory concentration: 70000 nM
For compound 3 the middle estimate is 1.9-fold (0.27 log units) above the measured one; low and high end bracket the measured number.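

With a single bromo on the aromatic carbon next to the ring nitrogen, this assay shows an at least 2.8-fold lower number from compound 2 to compound 3 (0.45 log units; beyond the scatter), so this one change is enough for a readable step. That step starts from a limit for compound 2 rather than a number: the limit of > 200000 nM in this assay, at which 1 of the 3 values shown sits. The further bromo of compound 1 brings no separable difference, the step being a 1.1-fold lower number from compound 1 to compound 3 (0.05 log units; within the scatter).

Going by these compounds, whether chloro, an amine or a longer chain on this same carbon would give a similar value remains open.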